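Adding a Methoxy Group to the Fluorophenyl Cinnamamide

This account rests on a few compounds, and the source may have more. Where it says the series, first, only, none or still open, it means among the compounds named here.

Measured so far, all in a functional assay on B16 cells (Mus musculus) for cytotoxicity, read by MTT assay, with a stated time of 72 h; a higher number here means a weaker inhibitor, a lower number a stronger inhibitor:
- compound 1 `COc1cccc(/C=C/C(=O)Nc2cc(C(=O)c3cc(OC)c(OC)c(OC)c3)ccc2OC)c1` gives 3100 nM
- compound 2 `C#CCOc1cccc(/C=C/C(=O)Nc2cc(C(=O)c3cc(OC)c(OC)c(OC)c3)ccc2OC)c1` gives 12200 nM
- compound 3 `COc1ccc(C(=O)c2cc(OC)c(OC)c(OC)c2)cc1NC(=O)/C=C/c1ccc(F)cc1` gives 400 nM

Among these three, compound 3 stands lowest, and both of its gaps to the others are beyond the scatter, so it is the strongest inhibitor of the set. The step from the 3-methoxyphenyl of compound 1 to the 4-fluorophenyl of compound 3 was a 7.8-fold lower number from compound 1 to compound 3 (0.89 log units; beyond the scatter), and from the larger 3-(propargyloxy)phenyl of compound 2 it was a 31-fold lower number from compound 2 to compound 3 (1.48 log units; beyond the scatter). Growing the methoxy into a propargyloxy gave a 3.9-fold higher number from compound 1 to compound 2 (0.59 log units; beyond the scatter).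

Compound 4 `COc1cc(/C=C/C(=O)Nc2cc(C(=O)c3cc(OC)c(OC)c(OC)c3)ccc2OC)ccc1F` keeps the fluorine of compound 3 and puts back a methoxy: methoxy in place of hydrogen on an aromatic carbon. Among the compounds with values here, no measured step adds a methoxy onto a ring that already carries a fluoro group, so the comparison is indirect. Compound 1 shows that the methoxy alone leaves a higher number than fluorine alone, and compound 2 shows that more bulk at that oxygen costs further. A combination is therefore expected to land near compound 3 or somewhat higher, estimated as a 1.8-fold higher number from compound 3 to compound 4 (0.24 log units; within the scatter).

For compound 4 the expected value in this assay is 700 nM, within a range from 250 nM to 2500 nM.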

Compound 4, half-maximal inhibitory concentration: 16300 nM
Compound 4: the middle estimate sits 23-fold (1.37 log units) below what was measured; the whole stated range lies below it.
By their numbers in this assay, from the lowest: compound 3; then compound 1; then compounds 2 and 4 (each within the scatter of the next).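

In this assay, adding a methoxy to the ring of compound 3, ortho to a fluoro group, proves far from neutral (a 41-fold higher number from compound 3 to compound 4 (1.61 log units; beyond the scatter)), and adding a fluoro to the ring of compound 1 also raises the number (a 5.3-fold higher number from compound 1 to compound 4 (0.72 log units; beyond the scatter)), so the 4-fluoro-3-methoxyphenyl group gives a weaker inhibitor than either the 4-fluorophenyl or the 3-methoxyphenyl group alone. The effects of the two groups therefore cannot be read as a simple compromise across these compounds, and the combined ring falls level with the 3-(propargyloxy)phenyl ring of compound 2 (a 1.3-fold higher number from compound 2 to compound 4 (0.13 log units; within the scatter)). Nothing available here explains this loss of activity.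

Going by these compounds, it remains open whether the loss is tied to the methoxy itself or would appear with other groups at this place, and a hydroxy group or a methyl group ortho to the fluoro group would test that. It is also unclear whether the fluorine is needed for the loss, which a chlorine in its place, with the methoxy kept, could help to show.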